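From Fluoro to Chloro in a Small Series

This account rests on a few compounds, and the source may have more. Where it says the series, first, only, none or still open, it means among the compounds named here.

Three related compounds have been measured in an ADME assay on Vero cells (Chlorocebus sabaeus) for cytotoxicity, read by resazurin assay, with a stated time of 72 h; on this read-out higher numbers stand for weaker inhibition and lower numbers for stronger inhibition. There, compound 1 `O=C(CCN1CCN(c2ccc(F)cc2)CC1)c1ccccc1` gives 13400 nM, compound 2 `Cc1ccc(C(=O)CCN2CCN(c3ccc(F)cc3)CC2)cc1` gives 55400 nM and compound 3 `COc1ccc(C(=O)CCN2CCN(c3ccc(F)cc3)CC2)cc1` gives 55000 nM. Compound 3 therefore stands level with compound 2, since swapping methyl for methoxy gives a 1.0-fold lower number from compound 2 to compound 3 (0.00 log units; within the scatter), which lies within the scatter. The two other measured steps are modest and go the same way: a 4.1-fold higher number from compound 1 to compound 2 (0.62 log units; beyond the scatter) and a 4.1-fold higher number from compound 1 to compound 3 (0.61 log units; beyond the scatter).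

Compound 4 `COc1ccc(C(=O)CCN2CCN(c3ccc(Cl)cc3)CC2)cc1` differs from compound 3 at a single place, with chloro in place of fluoro on an aromatic carbon. For the measured compounds named here, none of the measured steps touches this fluoro group, so the data show no direct example of this swap. They offer only a rough sense of how far one small substitution can move the number in this assay. The expectation therefore starts from compound 3 at 55000 nM, and the modest size of a 4.1-fold higher number from compound 1 to compound 3 (0.61 log units; beyond the scatter) guides the width of the range. No direction can be read from these data, so no change beyond the scatter is expected. The estimated step is a 1.2-fold lower number from compound 3 to compound 4 (0.09 log units; within the scatter). For compound 4 the estimated value is 45000 nM, with an expected range from 18000 nM to 100000 nM.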

Compound 4, half-maximal inhibitory concentration: 300000 nM
Beside the measured number, compound 4's estimate is 6.7-fold (0.82 log units) below it; the measured number lies above the stated range.
By their numbers in this assay, from the lowest: compound 1; then compounds 3 and 2 (each within the scatter of the next); then compound 4.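

In this assay, the swap gives a 5.5-fold higher number from compound 3 to compound 4 (0.74 log units; beyond the scatter), a change beyond the scatter towards weaker inhibition. For the compounds shown here, the earlier steps all left the 4-fluorophenyl group untouched, so this is the first sign that the number responds to this position, and that exchanging a single halogen atom on that aromatic carbon is enough to move it. No measurement shown here explains why this swap raises the number, so the result stands as an observation about this one pair of compounds.

As far as these compounds go, the evidence for this position rests on that single pair, which carries the methoxy group, so it remains open whether the same swap would move the number as far in the unsubstituted compound 1 or the methyl-bearing compound 2. Also open, from the compounds shown here alone, is how the number would respond to a bromo group, a nitrile or an amine on the same aromatic carbon, and whether the trend from fluoro to chloro continues or is particular to these two halogens.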